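The source may report more compounds than this note shows. Statements on the series, on what has been measured and on what is new or still open speak of the compounds shown alone.

Measured compounds:
compound 1 `O=C1COc2ccc(-c3cccc(NS(=O)(=O)c4ccc(F)cc4)c3)cc2N1c1ccccc1`: > 40000 nM
compound 2 `Cc1ccc(N2C(=O)COc3ccc(-c4cnc5ccccc5c4)cc32)cc1`: > 40000 nM

In a functional assay on A-375 cells (Homo sapiens) for antiproliferative activity, read by MTT assay, with a stated time of 72 h (a higher number here means a weaker inhibitor, a lower number a stronger inhibitor), compound 1 reaches only a limit of the assay, > 40000 nM. Compound 2 likewise gives only a limit, > 40000 nM. Both shown values sit at the same limit (the limit of > 40000 nM in this assay, at which 2 of the 2 values shown sit), so compound 2 stands at the edge of what the assay reports, with no number of its own. Compound 3 `O=C1COc2ccc(-c3cnc4ccccc4c3)cc2N1c1ccc(F)cc1` is not yet measured. The change from compound 2 to compound 3 is fluoro in place of methyl on an aromatic carbon. Among the compounds with values here, with no measured step to lean on, the expected step that the limit leaves unreadable from compound 2 to compound 3 is none beyond the scatter. Compound 3 is therefore estimated at about 50000 nM in this assay, between 15000 nM and 150000 nM, most likely again only as a limit.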

Compound 3, half-maximal inhibitory concentration: > 40000 nM
Compound 3: only a limit was reported; the forecaster's own chance of this, stated with the estimate: 80%; the middle value lies beyond the limit too.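

Compound 2 and compound 3 both end at a limit rather than a number, so fluoro in place of methyl gives no step that can be read: the limit of > 40000 nM in this assay, at which 3 of the 3 values shown sit.

The compounds shown leave open which change, if any, would give a true measured number.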